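Cytotoxicity notes on compounds 1 to 3

A few compounds are considered here, and "the series" means these few. Any claim that something is new, unique, unknown or untested is made for them only; others in the source may bear on it.

Measured so far:
compound 1 `CNC(=O)c1ccc(NCc2cncn2Cc2ccc(-c3ccccc3)cc2N)cc1-c1ccccc1`: > 1000 nM
compound 2 `COC(=O)c1ccc(NCc2cncn2Cc2ccccc2Cl)cc1-c1ccccc1`: 10000 nM
compound 3 `COC(=O)c1ccc(NCc2cncn2Cc2cccc(C#N)c2)cc1-c1ccccc1`: not yet measured

Among the compounds with values here, in a toxicity assay on NIH3T3 cells (Mus musculus) for cytotoxicity, read by resazurin assay (on this read-out higher numbers stand for an effect only at larger amounts of compound and lower numbers for an effect already at smaller amounts), compound 2 gives 10000 nM, the only number. Compound 1 reaches only a limit of this assay, > 1000 nM; the limit of > 1000 nM in this assay, at which 1 of the 2 values shown sits, marks it. Within the data shown here, no step between measured compounds exists, so compound 2 stands alone as a reference.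

Compound 3 differs from compound 2 by 3-cyanophenyl in place of 2-chlorophenyl on a saturated chain carbon bound to an aromatic nitrogen. Among the measured compounds shown here, with no measured step to lean on, the step from compound 2 to compound 3 is expected to stay within the scatter, no change at the digits printed from compound 2 to compound 3 (within the scatter). Compound 3 is therefore estimated at 10000 nM, with a range from 4000 nM to 25000 nM.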

Compound 3, half-maximal effective concentration: > 10000 nM
Compound 3 was reported as a limit; the forecaster's own chance of this, stated with the estimate: 40%; the middle value sits exactly at the limit.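

Within the data shown here, this is the first readable step: in this assay, 3-cyanophenyl in place of 2-chlorophenyl on a saturated chain carbon bound to an aromatic nitrogen gives a number no lower from compound 2 to compound 3 (the limit leaves the size open). This position therefore accepts the nitrile-bearing ring with no shift of the effect towards smaller amounts of compound. The result for compound 3 is a limit, not a number: the limit of > 10000 nM in this assay, at which 1 of the 3 values shown sits.

The compounds shown leave open how far apart compound 2 and compound 3 lie. They also leave open whether a carboxylic acid or a longer chain at this place would move the read-out.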